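Shortening the alkyl chain: compound 3 to compound 4

This account rests on a few compounds, and the source may have more. Where it says the series, first, only, none or still open, it means among the compounds named here.

Measured in a functional assay (spleen, spleen) for activation, with Mus musculus as the target; on this read-out higher numbers stand for an effect only at larger amounts of compound and lower numbers for an effect already at smaller amounts:
compound 1 `CCCCc1nc(N)c2nc(O)n(Cc3ccccc3)c2n1` gives 0.03 uM
compound 2 `CCCCNc1nc(N)c2nc(O)n(Cc3ccccc3)c2n1` gives 1 uM
compound 3 `CCCCSc1nc(N)c2nc(O)n(Cc3ccccc3)c2n1` gives 0.01 uM

Compound 3 has the lowest number of the three; the nearest is compound 1 with a 3.0-fold lower number from compound 1 to compound 3 (0.48 log units; beyond the scatter) in reverse, and compound 2 is furthest with a 100-fold lower number from compound 2 to compound 3 (2.00 log units; beyond the scatter). The change to compound 4 `CCCc1nc(N)c2nc(O)n(Cc3ccccc3)c2n1` is propyl in place of butylsulfanyl on an aromatic carbon. Within the data shown here, no measured step removes a sulfur and shortens a chain at once; the only bearing step is a 3.0-fold lower number from compound 1 to compound 3 (0.48 log units; beyond the scatter), which was modest. Among the measured compounds shown here, the new change also shortens the chain, for which no step exists, so a modest upward step is expected, a 5.0-fold higher number from compound 3 to compound 4 (0.70 log units; beyond the scatter). Compound 4 is therefore expected to give about 0.05 uM, between 0.01 uM and 0.3 uM.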

Compound 4, minimum effective concentration: 1 uM
Beside the measured number, compound 4's estimate is 20-fold (1.30 log units) below it; the measured number lies above the stated range.
By their numbers in this assay, from the lowest: compound 3; then compound 1; then compounds 2 and 4 (each within the scatter of the next).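

In this assay, shortening butyl to propyl on this aromatic carbon is itself a large step (a 33-fold higher number from compound 1 to compound 4 (1.52 log units; beyond the scatter)), so chain length here matters, not only the atom joining chain to core. The full exchange of butylsulfanyl for propyl is larger still (a 100-fold higher number from compound 3 to compound 4 (2.00 log units; beyond the scatter)), while propyl and butylamino cannot be told apart (no change at the digits printed from compound 2 to compound 4 (within the scatter)). Nothing available accounts for these steps.

Open, as far as these compounds go, is whether a pentyl chain or a butoxy group at this position would read with compound 1 and compound 3 or with compound 2 and compound 4.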